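A few compounds are considered here, and "the series" means these few. Any claim that something is new, unique, unknown or untested is made for them only; others in the source may bear on it.

Measured so far in an assay on isolated protein for inhibition of serine protease 1 (Homo sapiens), read by fluorescence; a lower number here means a stronger inhibitor, a higher number a weaker inhibitor: compound 1 `CNC(=O)[C@@H]1C[C@H](N2CCc3ccccc3C2)CN1C(=O)c1ccc(CN)c(OC)c1` gives 490 nM; compound 2 `CNC(=O)[C@@H]1C[C@H](N2CCc3c(cccc3OCCc3ccccc3)C2)CN1C(=O)c1ccc(CN)c(OC)c1` gives 3 nM; compound 3 `CNC(=O)[C@@H]1C[C@H](N2CCc3c(cccc3OCCC3CC3)C2)CN1C(=O)c1ccc(CN)c(OC)c1` gives 2 nM.

Compound 3 holds the lowest number of the three; compound 2 sits within the scatter of it, while compound 1 lies far above.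

Compound 4 `CNC(=O)[C@@H]1C[C@H](N2CCc3c(cccc3OCCOC)C2)CN1C(=O)c1ccc(CN)c(OC)c1` differs from compound 3 in one place: methoxy in place of cyclopropyl on a saturated chain carbon, two bonds along the chain from an oxygen on an aromatic ring.

Bearing on this: a 160-fold lower number from compound 1 to compound 2 (2.21 log units; beyond the scatter) and a 250-fold lower number from compound 1 to compound 3 (2.39 log units; beyond the scatter) show that the chain on the aromatic oxygen carries the large gain, whereas a 1.5-fold lower number from compound 2 to compound 3 (0.18 log units; within the scatter) shows that swapping the group at the end of the chain between phenyl and cyclopropyl changes nothing beyond the scatter. Going by the values given here, no measured step covers methoxy here, so a small step toward a higher number, within or only just beyond the scatter, is expected in this assay.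

Compound 4 is accordingly estimated at 6 nM, range 2 nM to 20 nM, an expected 3.0-fold higher number from compound 3 to compound 4 (0.48 log units; beyond the scatter).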

Compound 4, half-maximal inhibitory concentration: 8 nM
Beside the measured number, compound 4's estimate is 1.3-fold (0.12 log units) below it; the range from low to high includes it.
By their numbers in this assay, from the lowest: compounds 3 and 2 (each within the scatter of the next); then compound 4; then compound 1.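

In this assay, the group at the end of the chain does matter: methoxy in place of cyclopropyl gives a 4.0-fold higher number from compound 3 to compound 4 (0.60 log units; beyond the scatter), and methoxy in place of phenyl gives a 2.7-fold higher number from compound 2 to compound 4 (0.43 log units; beyond the scatter), whereas phenyl and cyclopropyl stayed within the scatter of each other. The 2-methoxyethoxy chain still keeps most of the gain over hydrogen, with a 61-fold lower number from compound 1 to compound 4 (1.79 log units; beyond the scatter). Nothing on hand explains the rise with methoxy.

The compounds shown leave open whether the rise follows the chain oxygen or the absence of a ring at the chain end. Going by these compounds, how a terminal amine or a carboxylic acid would read at this place also remains open.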